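Replacing a Sulfonyl Cap with a Benzyl Group

This account rests on a few compounds, and the source may have more. Where it says the series, first, only, none or still open, it means among the compounds named here.

Of the compounds shown here, two have so far been tested in a functional assay on HeLa cells (Homo sapiens) for cytotoxicity, read by MTT assay, with a stated time of 48 h; on this read-out higher numbers stand for weaker inhibition and lower numbers for stronger inhibition. Compound 1 `CCN(CC)c1ccc2cc(C(=O)c3ccc(N4CCN(C(=O)CN5CCN(S(=O)(=O)C6CC6)CC5)CC4)cc3)oc2c1` gives 28100 nM in this assay, and compound 2 `CCN(CC)c1ccc2cc(C(=O)c3ccc(N4CCN(C(=O)CN5CCN(S(=O)(=O)c6ccc(F)cc6)CC5)CC4)cc3)oc2c1` gives 16700 nM. Among the measured compounds shown here, the single measured step, a 1.7-fold lower number from compound 1 to compound 2 (0.23 log units; within the scatter), comes from putting a 4-fluorophenyl in place of a cyclopropyl on the sulfonyl sulfur. Compound 2 therefore has the lower of the two numbers, yet its gap to compound 1 lies within the scatter, so the two cannot be told apart on this read-out.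

Compound 3 `CCN(CC)c1ccc2cc(C(=O)c3ccc(N4CCN(C(=O)CN5CCN(Cc6ccc(C(F)(F)F)cc6)CC5)CC4)cc3)oc2c1` is not yet measured. It differs from compound 2 in one place: 4-(trifluoromethyl)benzyl in place of (4-fluorophenyl)sulfonyl on an amine nitrogen in a ring. For the measured compounds named here, no measured step bears directly on this change, since the only step known so far kept the sulfonyl group and merely exchanged the group attached to it, and that exchange stayed within the scatter. With nothing pointing either way, no movement beyond the scatter is expected for the step of a 1.1-fold lower number from compound 2 to compound 3 (0.05 log units; within the scatter). Compound 3 is accordingly estimated at 15000 nM in this assay, with a range from 4000 nM to 60000 nM.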

Compound 3, half-maximal inhibitory concentration: > 40000 nM
Compound 3 gave a limit, no number (the forecaster's own chance of this, stated with the estimate: 10%); at least 2.6-fold (0.42 log units) between middle value and limit.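

In this assay compound 3 gave a limit of the read-out and not a number: the limit of > 40000 nM in this assay, at which 1 of the 3 values shown sits.

Even so, this is the first change in the series that carries the read-out beyond the scatter: 4-(trifluoromethyl)benzyl in place of (4-fluorophenyl)sulfonyl on the amine nitrogen in the ring gives an at least 2.3-fold higher number from compound 2 to compound 3 (0.37 log units; beyond the scatter), which shows that what sits on this nitrogen can matter, and here the move is towards weaker inhibition, whereas exchanging the group on the sulfonyl sulfur earlier had stayed within the scatter. The same comparison against the other sulfonyl compound gives an at least 1.4-fold higher number from compound 1 to compound 3 (0.15 log units; that floor lies within the scatter), so this floor alone does not separate the benzyl compound from the cyclopropylsulfonyl one.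

Because two things change at once in this replacement, the sulfonyl link and the substituent on the aromatic ring, the data cannot say which of them accounts for the step; a plain benzyl or a 4-fluorobenzyl group on the same nitrogen would help to separate the two. Going by these compounds, whether a carbonyl link, as in a benzoyl group, or a simple methyl on this nitrogen would restore or further weaken inhibition also remains open.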